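A few compounds are considered here, and "the series" means these few. Any claim that something is new, unique, unknown or untested is made for them only; others in the source may bear on it.

Measured compounds:
compound 1, `COc1ccc(C(/C=C/c2ccc(F)cc2)=N/O)cc1`, in a functional assay (Mus musculus, strain Balb/c) for inhibition, read by ELISA, with a stated time of 72 h (a lower number here means a stronger inhibitor, a higher number a weaker inhibitor), compound 1 gives 11000 nM;
compound 2, `O/N=C(\C=C\c1ccc(F)cc1)c1ccc(Cl)cc1`, compound 2 gives 10600 nM;
compound 3, `O/N=C(\C=C\c1ccc(Cl)cc1)c1ccc(Br)cc1`, compound 3 gives 14700 nM.

All three numbers sit within the usual scatter of one another, so none of these compounds can be set apart from the others. Compound 3 is nearest to compound 1 and furthest from compound 2, and both gaps are within the scatter.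

Compound 4, `O/N=C(\C=C\c1ccc(F)cc1)c1ccc(Br)cc1`, has not been measured yet. Relative to compound 3 the change is fluoro in place of chloro on an aromatic carbon, on the ring farther from the oxime. Within the data shown here, the one measured single-site step, a 1.0-fold lower number from compound 1 to compound 2 (0.02 log units; within the scatter), swaps a group on the other ring and lies within the scatter; no measured step touches the ring that changes here. Compound 2 and compound 4 share the fluoro ring and differ only in bromo against chloro on the other ring, and compound 2 gives 10600 nM.

Compound 4 is therefore expected to show no step beyond the scatter, a 1.1-fold lower number from compound 3 to compound 4 (0.05 log units; within the scatter), and its estimated value is 13000 nM, within 6000 nM to 28000 nM.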

Compound 4, half-maximal inhibitory concentration: 13300 nM
Estimate against measurement, compound 4: 1.0-fold (0.01 log units) below; the range from low to high includes it.
By their numbers in this assay, from the lowest: compounds 2, 1, 4 and 3 (each within the scatter of the next).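

In this assay, among these compounds, fluoro in place of chloro on an aromatic carbon, para to a large group, gives a step that no earlier pair showed (a 1.1-fold lower number from compound 3 to compound 4 (0.04 log units; within the scatter)), so these two halogens cannot be told apart at this position. On the other ring, bromo in place of chloro (a 1.3-fold higher number from compound 2 to compound 4 (0.10 log units; within the scatter)) and bromo in place of methoxy (a 1.2-fold higher number from compound 1 to compound 4 (0.08 log units; within the scatter)) also stay within the scatter, so the three groups tried there cannot be separated either. No outside evidence bears on this result.

Still open, going by these compounds, is whether a quite different group at either position, such as an amine, a carboxylic acid or a longer chain, would move the number beyond the scatter. Also open, on these data alone, is how much the oxime itself matters, for example if a methyl ether took its place.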